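Replacing (ethoxycarbonyl)methyl with acetyl on the amine nitrogen

The source may hold more compounds than are shown below. What is called first, only, known or untested is meant among the compounds shown, and "the series" means these compounds.

Measured in a functional assay on Ehrlich cells (Mus musculus) for cytotoxicity, read by MTT assay, with a stated time of 24 h; a lower number here means a stronger inhibitor, a higher number a weaker inhibitor:
- compound 1 `COc1cc(C)cc2c1C(=O)C=C(c1c(C)cc3c(c1OC)C(=O)C(Nc1ccc(Cl)cc1)=CC3=O)C2=O`: 250 nM
- compound 2 `CCOC(=O)CNC1=CC(=O)c2cc(C)c(C3=CC(=O)c4c(OC)cc(C)cc4C3=O)c(OC)c2C1=O`: 90 nM

Compound 2 holds the lower of the two numbers. The next compound, compound 3 `COc1cc(C)cc2c1C(=O)C=C(c1c(C)cc3c(c1OC)C(=O)C(NC(C)=O)=CC3=O)C2=O`, carries acetyl in place of (ethoxycarbonyl)methyl on an amine nitrogen. For the measured compounds named here, one measured step bears on this, a change at that same nitrogen: a 2.8-fold lower number from compound 1 to compound 2 (0.44 log units; beyond the scatter). Going by the values given here, it is modest, and no compound with acetyl there has been measured, so the direction remains uncertain. The expected change is a 1.6-fold higher number from compound 2 to compound 3 (0.19 log units; within the scatter), a modest rise of similar size. Compound 3 is estimated at 140 nM, with an expected range of 45 nM to 420 nM.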

Compound 3, half-maximal inhibitory concentration: 60 nM
Estimate against measurement, compound 3: 2.3-fold (0.37 log units) above; the range from low to high includes it.
By their numbers in this assay, from the lowest: compounds 3 and 2 (each within the scatter of the next); then compound 1.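

In this assay, acetyl in place of (ethoxycarbonyl)methyl gives a 1.5-fold lower number from compound 2 to compound 3 (0.18 log units; within the scatter), so the two groups cannot be told apart at this amine nitrogen, even though acetyl is the smaller by heavy atoms. Acetyl in place of 4-chlorophenyl gives a 4.2-fold lower number from compound 1 to compound 3 (0.62 log units; beyond the scatter), so both groups now stand apart from 4-chlorophenyl, and the larger step belongs to acetyl. Nothing available explains these steps.

Going by these compounds, it remains open how an unsubstituted amine, a longer acyl chain or a carboxylic acid in place of the ethyl ester would compare at this nitrogen.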